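The source may report more compounds than this note shows. Statements on the series, on what has been measured and on what is new or still open speak of the compounds shown alone.

Measured in a functional assay on the whole organism (Hindlimb, strain albino) with Mus musculus as the target, in the maximal electroshock model, with a stated time of 0.5 h; on this read-out higher numbers stand for an effect only at larger amounts of compound and lower numbers for an effect already at smaller amounts:
- Compound 1 `Cc1ccc2nc(NC(=O)/C=C/OC3=CC=C3)sc2c1`: 505 umol/kg
- Compound 2 `O=C(/C=C/c1ccc(Cl)cc1)Nc1nc2ccccc2s1`: 367 umol/kg
- Compound 3 `Cc1ccc2nc(NC(=O)/C=C/c3ccc(O)cc3)sc2c1`: 271 umol/kg

The value of compound 3 lies within the usual scatter of the values of both other compounds, so these numbers set no order among the three. Compound 4 `O=C(/C=C/c1ccc(O)cc1)Nc1nc2ccccc2s1` departs from compound 3 by a single change, hydrogen in place of methyl on an aromatic carbon.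

Among the measured compounds shown here, no measured step isolates this change. For the measured compounds named here, the only step available, a 1.9-fold lower number from compound 1 to compound 3 (0.27 log units; within the scatter), involves a different group in a different place and stays within the scatter. Compound 2, at 367 umol/kg, also has hydrogen in place of that methyl, but it differs from compound 3 in a second group as well, so its value cannot show the effect of this change alone.

Nothing measured therefore points to a shift beyond the scatter in this assay. The expected change is small, a 1.1-fold higher number from compound 3 to compound 4 (0.04 log units; within the scatter). For compound 4 the estimated value is 300 umol/kg, with an expected range of 150 umol/kg to 600 umol/kg.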

Compound 4, dose for half-maximal effect: 517 umol/kg
Estimate against measurement, compound 4: 1.7-fold (0.24 log units) below; low and high end bracket the measured number.
By their numbers in this assay, from the lowest: compounds 3, 2, 1 and 4 (each within the scatter of the next).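

Among the compounds shown here, this is the first direct look at this position: in this assay, taking away the methyl gives a 1.9-fold higher number from compound 3 to compound 4 (0.28 log units; within the scatter), so with only this pair, hydrogen and methyl on this aromatic carbon cannot be told apart. Compound 2 and compound 4 share a core without that methyl and differ only in the group on the other aromatic ring, and hydroxy in place of chloro gives a 1.4-fold higher number from compound 2 to compound 4 (0.15 log units; within the scatter), so this swap cannot be told apart either. No outside measurement bears on these results.

The compounds shown carry only hydrogen or methyl at the first position, so it stays open whether a larger group, such as methoxy or an amine, would give a step beyond the scatter. Going by these compounds, on the other aromatic ring, a carboxylic acid in place of the hydroxy remains equally open.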